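A few compounds are considered here, and "the series" means these few. Any claim that something is new, unique, unknown or untested is made for them only; others in the source may bear on it.

Compound 1 `CN1C(=O)/C(=C/c2ccc(OCc3ccc(F)cc3)cc2)S/C1=N/c1cccc(C(=O)O)c1` was tested in an assay for inhibition of dual specificity protein phosphatase 26 (Homo sapiens), read by fluorescence, with a stated time of 30 min (a higher number here means a weaker inhibitor, a lower number a stronger inhibitor), where compound 1 gives 26900 nM. Compound 2 `O=C(O)c1ccc(Cl)cc1Nc1nc2ccccc2nc1NS(=O)(=O)c1ccc(Cl)cc1` gives 17000 nM in this assay, and the two values sit within the usual scatter of each other, so neither compound can be ranked against the other. Compound 3 `Cc1ccc(C2=C/C(=C\c3ccc(-c4cccc(C(=O)O)c4)o3)C(=O)O2)cc1` reached only a limit, > 100000 nM, in this assay, and this is the limit of > 100000 nM in this assay, at which 1 of the 3 values shown sits, rather than a number. Compound 4 `CN1C(=O)/C(=C/c2ccc(OCc3cccc([N+](=O)[O-])c3)cc2)S/C1=N/c1cccc(C(=O)O)c1` has not yet been measured. It differs from compound 1 in one place: 3-nitrophenyl in place of 4-fluorophenyl on a saturated chain carbon bound to an oxygen on an aromatic ring. Among the compounds with values here, no pair of measured compounds shows this change, so its effect cannot be read from the numbers at hand. The expected step, a 1.0-fold higher number from compound 1 to compound 4 (0.00 log units; within the scatter), is none beyond the scatter, in either direction. Compound 4 is therefore expected to give about 27000 nM in this assay, with a likely range from 9000 nM to 80000 nM.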

Compound 4, half-maximal inhibitory concentration: 19800 nM
Compound 4: the middle estimate sits 1.4-fold (0.13 log units) above what was measured, and the stated range covers the measured number.
By their numbers in this assay, from the lowest: compounds 2, 4 and 1 (each within the scatter of the next). At a limit, above all of these: compound 3.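

Within the data shown here, no pair of compounds differing in one place was available before, so nothing could be read about the group on a saturated chain carbon bound to an oxygen on an aromatic ring. In this assay, 3-nitrophenyl in place of 4-fluorophenyl at this place gives a 1.4-fold lower number from compound 1 to compound 4 (0.13 log units; within the scatter) and so the two compounds cannot be ranked. The position therefore takes a group of 9 heavy atoms with 2 hydrogen-bond acceptors in place of one with 7 heavy atoms and 0 acceptors, with no difference that can be told from the scatter.

On these data alone, whether an amine on this phenyl ring, or a longer chain in place of the benzyl group, would give a step beyond the scatter remains open. What lies behind this step also stays open, as no measurement shown bears on it.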